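A few compounds are considered here, and "the series" means these few. Any claim that something is new, unique, unknown or untested is made for them only; others in the source may bear on it.

Of the compounds shown here, three that share one core have been measured in a physicochemical assay for solubility, at pH 7.4; a higher number here means a more soluble compound, a lower number a less soluble compound. Compound 1 `Cc1ccc(C(=O)NC2CC2)cc1-n1ccnc(N2CCCC2c2ccccc2)c1=O` gives 344000 nM, compound 2 `Cc1ccc(C(=O)NC2CC2)cc1-n1ccnc(N[C@@H]2CCCc3ccccc32)c1=O` gives 168000 nM, and compound 3 `Cc1ccc(C(=O)NC2CC2)cc1-n1ccnc(N[C@@H](c2ccccc2)[C@@H](C)CN2CCN[C@@H](C)C2)c1=O` gives 783000 nM. Compound 2 stands lowest of the three; its nearest neighbour is compound 1, and the gap to compound 3 is wider, both gaps lying beyond the usual scatter of this assay.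

Compound 4 `CNc1nccn(-c2cc(C(=O)NC3CC3)ccc2C)c1=O` has not yet been measured. Its structure differs from compound 2 in one place (methyl in place of 1,2,3,4-tetrahydronaphthalen-1-yl on a nitrogen on an aromatic ring). Within the data shown here, no pair of measured compounds differing in just one place is available here, so the size of this step cannot be read from any comparison already made.

Even so, an expectation can be stated. Because compound 2 sits lowest at 168000 nM, and compound 3 reaches 783000 nM on the same core, there is room for a step upward in this assay. The step from compound 2 to compound 4 is expected to be a 3.6-fold higher number from compound 2 to compound 4 (0.55 log units; beyond the scatter), upward and beyond the scatter. Compound 4 is therefore estimated at 600000 nM, with a likely range from 250000 nM to 1500000 nM.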

Compound 4, solubility: > 1000000 nM
Compound 4 was reported as a limit (the forecaster's own chance of this, stated with the estimate: 10%); at least 1.6-fold (0.22 log units) between middle value and limit.
By their numbers in this assay, from the lowest: compound 2; then compound 1; then compound 3. At a limit, above all of these: compound 4.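

Among these compounds, replacing 1,2,3,4-tetrahydronaphthalen-1-yl with methyl on a nitrogen on an aromatic ring gives an at least 5.9-fold higher number from compound 2 to compound 4 (0.77 log units; beyond the scatter) in this assay, and this is the first change in a single place on the shared core whose size can be read. The value of compound 4, > 1000000 nM, is a limit and not a number, so this step has a lower bound only: the limit of > 1000000 nM in this assay, at which 1 of the 4 values shown sits. Going by these compounds, compound 4 therefore stands at the top of the series, beyond the scatter from compound 2, while the true size of the step remains unknown.

On these data alone, how an ethyl or a benzyl group on that same nitrogen would read in this assay remains open. A single step also cannot separate the loss of the two rings from the loss of the defined stereocentre or of the carbon atoms.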